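Methyl in place of chloro: working notes on compounds 1 to 4

The source may report more compounds than this note shows. Statements on the series, on what has been measured and on what is new or still open speak of the compounds shown alone.

Measured so far, in a functional assay on MCF7 cells (Homo sapiens) for cytotoxicity; on this read-out higher numbers stand for weaker inhibition and lower numbers for stronger inhibition:
compound 1, `Nc1ccc(-c2nc3cc(O)ccc3s2)cc1Cl`, compound 1 gives 60600 nM
compound 2, `CC(=O)Nc1ccc(-c2nc3ccc(O)cc3s2)cc1C`, compound 2 gives 46100 nM
compound 3, `CC(=O)Nc1ccc(-c2nc3ccc(O)cc3s2)cc1Cl`, compound 3 gives 71200 nM

Compounds 2 and 3 share a core and differ in one place: methyl in place of chloro on an aromatic carbon. In this assay this gave a 1.5-fold lower number from compound 3 to compound 2 (0.19 log units; within the scatter). Compound 1 and compound 3 differ elsewhere as well; the difference between the two cores is not broken down here. For the measured compounds named here, the three numbers so far all sit within the scatter of one another, so no order among compounds 1, 2 and 3 is claimed.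

Compound 4, `Cc1cc(-c2nc3cc(O)ccc3s2)ccc1N`, is not yet measured. From compound 1 it differs by methyl in place of chloro on an aromatic carbon. Going by the values given here, this is the same kind of change as the one from compound 3 to compound 2, not the same: in compound 1 the place is ortho to an amino group, in compound 3 ortho to an acetamido group. Among the compounds with values here, since the one measured instance of this kind of change was small, the step from compound 1 to compound 4 is expected to be a 1.3-fold lower number from compound 1 to compound 4 (0.13 log units; within the scatter), resting on a 1.5-fold lower number from compound 3 to compound 2 (0.19 log units; within the scatter). In this assay compound 4 is therefore estimated at 45000 nM, expected to lie between 22000 nM and 95000 nM.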

Compound 4, half-maximal inhibitory concentration: 78700 nM
Beside the measured number, compound 4's estimate is 1.7-fold (0.24 log units) below it; the range from low to high includes it.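

In this assay methyl in place of chloro gives a 1.3-fold higher number from compound 1 to compound 4 (0.11 log units; within the scatter) and stays small on this second core, and the two steps do not differ beyond what repeat measurements would allow: the same change on two cores in this assay, a 1.5-fold lower number (0.19 log units; within the scatter) from compound 3 to compound 2 and a 1.3-fold higher number (0.11 log units; within the scatter) from compound 1 to compound 4, 2.0-fold (0.30 log units) apart, within the scatter of two such steps
On this read-out, then, the change carries from the core of compound 3 to the core of compound 1 without a detectable difference between the two steps, which supports using one step to estimate the other within this series. It does not show a direction for the change, since each step lies within the scatter, and two pairs cannot show that the change would stay small on other cores or with other groups on the same ring.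

With only chloro and methyl at this place, the compounds shown leave open what an ethyl group, a methoxy group or a nitrile would give there. They also leave open how the amino group and the acetamido group compare on one shared core, and whether a carboxylic acid or a longer chain on that nitrogen would move the number at all.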